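The source may report more compounds than this note shows. Statements on the series, on what has been measured and on what is new or still open speak of the compounds shown alone.

Compound 1 `COc1cc(CN2c3ccc(O)cc3C(C)=CC2(C)C)cc(OC)c1`: 11000 nM
Compound 2 `CC(=O)Oc1ccc2c(c1)C(C)=CC(C)(C)N2Cc1ccc(C#N)cc1`: 29000 nM
Compound 3 `COc1cc(OC)cc(C(=O)Oc2ccc3c(c2)C(C)=CC(C)(C)N3Cc2ccc(C)cc2)c1`: > 200000 nM

In an ADME assay on L6 cells (Rattus norvegicus) for cytotoxicity, read by resazurin assay, with a stated time of 70 h (a lower number here means a stronger inhibitor, a higher number a weaker inhibitor), compound 2 gives 29000 nM, the higher of the two numbers. Compound 1 gives 11000 nM, a lower number that lies beyond the scatter. For compound 3 the value > 200000 nM is a limit of the assay, not a number. Compound 4 `CC(=O)Oc1ccc2c(c1)C(C)=CC(C)(C)N2C` has not yet been measured. It differs from compound 2 in one place: hydrogen in place of 4-cyanophenyl on a saturated chain carbon bound to a nitrogen on an aromatic ring in a ring. Within the data shown here, no measured pair shows this kind of change, so the size of the step cannot be read from the data. A moderate rise in the number, beyond the scatter, is expected. Compound 4 is therefore estimated at 60000 nM, with a range from 20000 nM to 200000 nM. The step this estimate means is expected to be a 2.1-fold higher number from compound 2 to compound 4 (0.32 log units; beyond the scatter).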

Compound 4, half-maximal inhibitory concentration: 41000 nM
Compound 4: the middle estimate sits 1.5-fold (0.17 log units) above what was measured, and the stated range covers the measured number.
By their numbers in this assay, from the lowest: compound 1; then compounds 2 and 4 (each within the scatter of the next). At a limit, above all of these: compound 3.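

In this assay, hydrogen in place of 4-cyanophenyl on a saturated chain carbon bound to a nitrogen on an aromatic ring in a ring gives a 1.4-fold higher number from compound 2 to compound 4 (0.15 log units; within the scatter) and so no clear change. This first pair differing in one place shows that, for these two compounds, the number does not depend on keeping that whole aromatic group. Nothing measured here explains this result.

Going by these compounds, whether a carboxylic acid or a longer chain at this place would shift the number beyond the scatter stays open. Also open, on these data alone, is whether the same change would behave alike on the core of compound 1.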